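This account rests on a few compounds, and the source may have more. Where it says the series, first, only, none or still open, it means among the compounds named here.

Measured in a functional assay on MCF7 cells (Homo sapiens) for inhibition, read by resazurin assay, with a stated time of 72 h; on this read-out lower numbers stand for stronger inhibition and higher numbers for weaker inhibition:

Compound 1 `COc1ccc(C2C(O)C(=O)N2c2cc(OC)c(OC)c(OC)c2)cc1`: 4 nM
Compound 2 `COc1cc(N2C(=O)C(C3CC3)C2c2ccc(SC)cc2)cc(OC)c1OC`: 131 nM

Of these two, compound 2 has the higher number, at 131 nM, and so the weaker inhibition. Its gap to compound 1, at 4 nM, lies beyond the usual scatter. Going by the values given here, the two compounds differ in more than one place, however, and no step at a single place has been measured, so the gap cannot be assigned to any one group.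

Compound 3 `COc1cc(N2C(=O)C(O)C2c2ccc(SC)cc2)cc(OC)c1OC` is derived from compound 2 by one change: hydroxy in place of cyclopropyl on a saturated ring carbon. The 4-(methylsulfanyl)phenyl group stays as it is. Among the compounds with values here, the only guide to the new group is compound 1, which also carries hydroxy and gives 4 nM. This is indirect evidence, so the expectation stays broad. A drop in the number beyond the scatter is expected, with the estimated step being a 6.6-fold lower number from compound 2 to compound 3 (0.82 log units; beyond the scatter). Compound 3 is estimated at 20 nM, with an expected range of 5 nM to 80 nM.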

Compound 3, half-maximal inhibitory concentration: 5 nM
Compound 3: middle estimate off by 4.0-fold (0.60 log units), on the high side; the measured number falls inside the stated range.
By their numbers in this assay, from the lowest: compounds 1 and 3 (each within the scatter of the next); then compound 2.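

In this assay, putting hydroxy in place of cyclopropyl on the saturated ring carbon gives the first step measured at this position alone (a 26-fold lower number from compound 2 to compound 3 (1.42 log units; beyond the scatter)), and that step is large and beyond the scatter. With hydroxy on that carbon, exchanging methoxy for methylsulfanyl on an aromatic carbon gives a step within the scatter (a 1.3-fold higher number from compound 1 to compound 3 (0.10 log units; within the scatter)), so in this pair the two groups cannot be told apart on this read-out. The compounds shown offer no independent measurement that could explain either step.

From the compounds shown here alone, what remains open is how other groups on this ring carbon would compare, such as an amine, a carboxylic acid or a longer chain, since only hydroxy and cyclopropyl appear there. It is also unknown whether methoxy and methylsulfanyl would remain indistinguishable with cyclopropyl on the ring carbon, as the cyclopropyl group is seen here only in compound 2, alongside methylsulfanyl.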